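A few compounds are considered here, and "the series" means these few. Any claim that something is new, unique, unknown or untested is made for them only; others in the source may bear on it.

Working notes on the series. The common core carries a thiourea whose aryl group is varied. Compound 1 `COc1cc2c(cc1OC)C(=O)C(CC1CCN(C(=S)Nc3ccccc3)CC1)C2` bears an unsubstituted phenyl; in a functional assay on the whole organism (strain Swiss albino) with Mus musculus as the target, in the maximal electroshock model, with a stated time of 0.5 h (on this read-out lower numbers stand for an effect already at smaller amounts and higher numbers for an effect only at larger amounts of compound), compound 1 gives 100 mg/kg. Compound 2 `COc1cc2c(cc1OC)C(=O)C(CC1CCN(C(=S)Nc3ccccc3C)CC1)C2` adds a methyl on an aromatic carbon, and in this assay compound 2 gives 100 mg/kg, so that no change at the digits printed from compound 1 to compound 2 (within the scatter). Compound 3 `COc1cc2c(cc1OC)C(=O)C(CC1CCN(C(=S)Nc3ccccc3Cl)CC1)C2` carries a chloro on an aromatic carbon instead; in this assay compound 3 gives 100 mg/kg, with no change at the digits printed from compound 1 to compound 3 (within the scatter) and no change at the digits printed from compound 2 to compound 3 (within the scatter). Compound 3 therefore stands level with compounds 1 and 2 at the digits shown.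

Compound 4 `COc1cc2c(cc1OC)C(=O)C(CC1CCN(C(=S)Nc3cccc(Cl)c3)CC1)C2` is the next step: 3-chlorophenyl in place of 2-chlorophenyl on an amide-type nitrogen. Going by the values given here, no measured step moves a chloro between aromatic carbons; the three steps at hand all concern a substituent on an aromatic carbon of the same ring, and each stayed within the scatter. On that basis the step is expected to be no change at the digits printed from compound 3 to compound 4 (within the scatter), with no movement beyond the scatter. In this assay compound 4 is estimated at 100 mg/kg, within a range of 50 mg/kg to 200 mg/kg.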

Compound 4, minimum effective dose: 300 mg/kg
Estimate against measurement, compound 4: 3.0-fold (0.48 log units) below; measured number above the stated range.
By their numbers in this assay, from the lowest: compounds 1, 2 and 3 (each within the scatter of the next); then compound 4.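

In this assay, going by these compounds alone, the place of the chloro on the aryl group matters, which the earlier compounds could not show: 3-chlorophenyl in place of 2-chlorophenyl on the amide-type nitrogen gives a 3.0-fold higher number from compound 3 to compound 4 (0.48 log units; beyond the scatter) and is the first step beyond the scatter. The 2-methylphenyl and unsubstituted phenyl comparisons agree, with a 3.0-fold higher number from compound 2 to compound 4 (0.48 log units; beyond the scatter) and a 3.0-fold higher number from compound 1 to compound 4 (0.48 log units; beyond the scatter), so chloro in place of hydrogen leaves the number unchanged with 2-chlorophenyl but not with 3-chlorophenyl. Nothing at hand explains this shift.

Whether the shift is specific to chloro or would follow any group at this place remains open, since 3-methylphenyl and 3-methoxyphenyl are absent from the compounds shown. Also open, from the compounds shown here alone, is how a benzyl or a cyclohexyl would read in place of the aryl group on this nitrogen.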